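The source may hold more compounds than are shown below. What is called first, only, known or untested is meant among the compounds shown, and "the series" means these compounds.

Compound 1 `O=C1c2ccc(OCc3cccc(-c4ccc(C(F)(F)F)cc4F)c3)cc2CN1C1CCCC1` has no number of its own here: in an ADME assay on a cell-free system (plasma, Rattus norvegicus) for metabolic stability, read by LC-MS, with a stated time of 1 h, at 37 degrees C, tested at 100 uM (on this read-out lower numbers stand for a less stable compound and higher numbers for a more stable compound), compound 1 carries only the entry "not determined" (no result reported), so no result was reported, and nothing can be said of where it stands. Two other compounds from the same study were read. Compound 2 `O=C(O)c1cc(-c2cccc(COc3ccc4c(=O)n(CC5CC5)sc4c3)c2)ccc1Cl` gives 100% in this assay, and compound 3 `O=C(O)c1cc(-c2cccc(COc3ccc4c(=O)n(C5CCCC5)sc4c3)c2)cc([N+](=O)[O-])c1` gives 100% in the same assay. These two share neither the core nor the full substitution of compound 1, so they mark only what this assay has reported so far, not a step.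

Compound 4 `O=C1c2ccc(OCc3cccc(-c4ccccc4)c3)cc2CN1C1CCCC1` differs from compound 1 in one place: phenyl in place of 2-fluoro-4-(trifluoromethyl)phenyl on an aromatic carbon. For the measured compounds named here, no measured pair shows what such a change does in this assay, so no direction can be read from the data; any step is expected to stay within the usual scatter, neither clearly up nor down.

Given that compound 2 reached 100% and compound 3 reached 100%, compound 4 is estimated to remain largely intact, at about 95%, with a range from 80% to 100%.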

Compound 4, percent of the compound remaining: 95%
Beside the measured number, compound 4's estimate shows no gap at the digits printed, within the range that was stated.
By their numbers in this assay, from the lowest: compounds 4, 2 and 3 (each within the scatter of the next).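

For the compounds shown here, with compound 1 carrying no number in this assay, no step between compound 1 and compound 4 can be read. No evidence on hand bears on this result. Going by these compounds, what the change from 2-fluoro-4-(trifluoromethyl)phenyl to phenyl does in this assay stays open.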